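Bromo to trifluoromethyl in the anilino series

The compounds below may be only part of what the source reports. "The series", "measured", "known", "first", "only" and "open" are said of these compounds alone.

Measured in a functional assay on ECa-109 cells for inhibition, with ECa-109 cell line (Homo sapiens) as the target, read by sulforhodamine B assay; on this read-out lower numbers stand for stronger inhibition and higher numbers for weaker inhibition:
compound 1 `O=C1C(Nc2ccccc2)=CC(=O)c2c1nc1n2[C@H]2OC[C@@H](O)[C@H]2OC1` gives 3560 nM
compound 2 `O=C1C(Nc2ccc(Br)cc2)=CC(=O)c2c1nc1n2[C@H]2OC[C@@H](O)[C@H]2OC1` gives 1980 nM
compound 3 `O=C1C(N2CCCC2)=CC(=O)c2c1nc1n2[C@H]2OC[C@@H](O)[C@H]2OC1` gives > 16000 nM (a limit of the assay)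

Going by the values given here, compound 2 lies within the scatter of compound 1, and these two hold the only actual numbers. Compound 4 `O=C1C(Nc2ccc(C(F)(F)F)cc2)=CC(=O)c2c1nc1n2[C@H]2OC[C@@H](O)[C@H]2OC1` carries trifluoromethyl in place of bromo on an aromatic carbon. The closest measured change at that carbon is a 1.8-fold lower number from compound 1 to compound 2 (0.25 log units; within the scatter). The larger steps of an at least 4.4-fold higher number from compound 1 to compound 3 (0.65 log units; beyond the scatter) and an at least 8.0-fold higher number from compound 2 to compound 3 (0.90 log units; beyond the scatter) replace the whole anilino group, so they bear less on this change. No step beyond the scatter is expected in this assay, and the estimated change is a 1.1-fold higher number from compound 2 to compound 4 (0.05 log units; within the scatter). For compound 4 the estimate is 2200 nM, with an expected range of 1000 nM to 5000 nM.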

Compound 4, half-maximal inhibitory concentration: 2250 nM
Compound 4: middle estimate off by 1.0-fold (0.01 log units), on the low side; the range from low to high includes it.
By their numbers in this assay, from the lowest: compounds 2, 4 and 1 (each within the scatter of the next). At a limit, above all of these: compound 3.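

In this assay, trifluoromethyl on this aromatic carbon gives no separation from bromo (a 1.1-fold higher number from compound 2 to compound 4 (0.06 log units; within the scatter)) or from hydrogen (a 1.6-fold lower number from compound 1 to compound 4 (0.20 log units; within the scatter)). Compounds 1, 2 and 4 therefore hold together within the scatter, and neither substituent on this carbon yet shows a measurable step. Nothing measured here bears on why these values stay together.

Still open, from the compounds shown here alone, is whether an amine or a carboxylic acid in place of trifluoromethyl would give a step beyond the scatter.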